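A Halogen Swap on an Aryl Ring, Measured Against a Limit

This account rests on a few compounds, and the source may have more. Where it says the series, first, only, none or still open, it means among the compounds named here.

All three measured compounds were tested in a functional assay on HeLa cells (Homo sapiens) for cytotoxicity, with a stated time of 72 h; a lower number here means a stronger inhibitor, a higher number a weaker inhibitor:
Compound 1 `Clc1ccc(-c2cn3nc(Cl)sc3n2)cc1` gives 95000 nM.
Compound 2 `Clc1ccc(Cc2nn3cc(-c4ccc(Br)cc4)nc3s2)cc1` gives > 250000 nM, a limit of this assay and not a number.
Compound 3 `COc1ccc(-c2cn3nc(Cl)sc3n2)cc1` gives > 250000 nM, also a limit.

Compound 2 thus stands at the limit of this assay, and the limit of > 250000 nM in this assay, at which 2 of the 3 values shown sit, shows that it shares this place with one other compound. Compound 4 `Clc1ccc(Cc2nn3cc(-c4ccc(Cl)cc4Cl)nc3s2)cc1` differs from compound 2 by 2,4-dichlorophenyl in place of 4-bromophenyl on an aromatic carbon. For the measured compounds named here, the only measured step, an at least 2.6-fold higher number from compound 1 to compound 3 (0.42 log units; beyond the scatter), concerns a different group at a different place, so no measured step bears directly on this change. As compound 2 is already at the limit, little movement is expected: the step is estimated as an at least 1.2-fold lower number from compound 2 to compound 4 (0.09 log units; that floor lies within the scatter). Compound 4 is expected to give 200000 nM, between 60000 nM and 600000 nM, quite possibly again as a limit.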

Compound 4, half-maximal inhibitory concentration: 109000 nM
Compound 4: the middle estimate sits 1.8-fold (0.26 log units) above what was measured, within the range that was stated.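

Replacing 4-bromophenyl with 2,4-dichlorophenyl at this position gives an at least 2.2-fold lower number from compound 2 to compound 4 (0.36 log units; beyond the scatter) in this assay. Of this pair, only compound 4 gives a number, so the group on this aromatic carbon can shift the read-out. Compound 2 gives a limit and not a number, so the step is only a floor: the limit of > 250000 nM in this assay, at which 2 of the 4 values shown sit.

The change swaps bromine for chlorine and adds a second chlorine in one move, so the pair cannot separate those two parts. On these data alone, how an amine or a carboxylic acid on this phenyl ring would fare remains open.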